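This account rests on a few compounds, and the source may have more. Where it says the series, first, only, none or still open, it means among the compounds named here.

In an ADME assay on J774 cells (Mus musculus, strain BALB/c) for cytotoxicity, read by resazurin assay, with a stated time of 72 h (on this read-out lower numbers stand for higher toxicity in this test and higher numbers for lower toxicity in this test), compound 1, `CC(/C=N/Nc1ccc([N+](=O)[O-])cc1)=N\NC(=O)c1ccccc1Nc1ccccc1`, returns only a limit of the assay, > 100000 nM. Compound 2, `CC(/C=N/Nc1ccc([N+](=O)[O-])cc1)=N\NC(=O)c1ccc(N)cc1`, gives 75000 nM in this assay. Compound 3, `CC(/C=N/N(C)c1ccc([N+](=O)[O-])cc1)=N\NC(=O)c1ccccc1O`, gives 31500 nM in this assay. Among the two numbers shown, compound 2 stands highest, with compound 3 as its nearest neighbour at a lower value that lies beyond the scatter; the remaining value is the limit of > 100000 nM in this assay, at which 1 of the 3 values shown sits.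

Compound 4, `COc1cc(C(=O)N/N=C(C)/C=N/Nc2ccc([N+](=O)[O-])cc2)ccc1O`, differs from compound 2 by 4-hydroxy-3-methoxyphenyl in place of 4-aminophenyl on a carbonyl carbon. Going by the values given here, no pair of measured compounds isolates this change, so the size of its effect has no precedent here. The step from compound 2 to compound 4 is expected to be a 1.3-fold lower number from compound 2 to compound 4 (0.10 log units; within the scatter), not beyond the scatter in either direction. Compound 4 is therefore estimated at 60000 nM in this assay, with a range from 20000 nM to 150000 nM.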

Compound 4, half-maximal cytotoxic concentration: > 100000 nM
Compound 4: only a limit was reported; the forecaster's own chance of this, stated with the estimate: 30%; middle value at least 1.6-fold (0.22 log units) away from the limit.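

Going by these compounds alone, at the carbonyl carbon, 4-hydroxy-3-methoxyphenyl in place of 4-aminophenyl brings an at least 1.3-fold higher number from compound 2 to compound 4 (0.12 log units; that floor lies within the scatter) in this assay, the first step that can be read at this place. Going by these compounds, compound 4 returns only a limit of the assay, so this step is a floor and its true size remains unknown. The change gives no sign of a lower number, and the limit now recurs among the values: the limit of > 100000 nM in this assay, at which 2 of the 4 values shown sit.

The compounds shown leave open how a carboxylic acid or a longer chain on this carbonyl carbon would read. They also cannot separate the hydroxy group from the methoxy group within this change.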